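The source may report more compounds than this note shows. Statements on the series, on what has been measured and on what is new or still open speak of the compounds shown alone.

In an ADME assay on HepG2 cells (Homo sapiens) for cytotoxicity, read by CellTiter-Glo and ATP content, with a stated time of 72 h (on this read-out higher numbers stand for an effect only at larger amounts of compound and lower numbers for an effect already at smaller amounts), three compounds of the shared core have been measured. Compound 1 `CS(=O)(=O)c1ccc(C(=O)NCC(=O)N(Cc2ccccc2)Cc2ccccc2)cc1[N+](=O)[O-]` gives 11900 nM. Compound 2 `CN(CC(=O)N1CCN(c2ccccc2)CC1)C(=O)c1ccc(S(C)(=O)=O)c([N+](=O)[O-])c1` reaches only a limit of the assay, > 27000 nM. Compound 3 `CCCN(C(=O)CN(C)C(=O)c1ccc(S(C)(=O)=O)c([N+](=O)[O-])c1)c1ccccc1` likewise reaches only a limit, > 27000 nM. Compound 2 thus stands at the limit of > 27000 nM in this assay, at which 2 of the 3 values shown sit, and no number is known for it in this assay, only that limit.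

Compound 4 `CN(CC(=O)N1CCN(c2ccc(F)cc2)CC1)C(=O)c1ccc(S(C)(=O)=O)c([N+](=O)[O-])c1` has not yet been measured in this assay. It differs from compound 2 by fluoro in place of hydrogen on an aromatic carbon. Within the data shown here, no step between two measured compounds is available here to size such a change, so the expectation rests on where compound 2 stands alone. For compound 4 the step that the limit leaves unreadable from compound 2 to compound 4 is expected to be none beyond the scatter, because compound 2 stands at the limit of > 27000 nM in this assay, at which 2 of the 3 values shown sit, and nothing shown points away from it. Compound 4 is therefore estimated in this assay at 30000 nM, with a range from 12000 nM to 70000 nM, and most likely the assay again reports only its limit.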

Compound 4, half-maximal effective concentration: 17200 nM
Estimate against measurement, compound 4: 1.7-fold (0.24 log units) above, within the range that was stated.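

In this assay, the change from phenyl to 4-fluorophenyl, placed para to a large group, gives an at least 1.5-fold lower number from compound 2 to compound 4 (0.19 log units; that floor lies within the scatter). Compound 2 reached only a limit of the assay. Among these compounds, compound 4 gives a number, 17200 nM, so this position now has a first measured value for a compound carrying a single added fluorine atom. The real size of the change cannot be read, however, and it may be larger than that floor, because only a limit stands at its starting point: the limit of > 27000 nM in this assay, at which 2 of the 4 values shown sit.

The compounds shown leave open how a chlorine atom, a methoxy group or an amine on the same aromatic carbon would read in this assay. They also leave open whether fluoro would give a similar step on the phenyl of compound 3.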